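Straightening tert-butyl into butyl on compound 3

The compounds below may be only part of what the source reports. "The series", "measured", "known", "first", "only" and "open" are said of these compounds alone.

Compounds measured so far:
Compound 1, `CCCc1ccc(/C=C/C(=O)Nc2ccc3nc(CCC)cc(N)c3c2)cc1`, gives 3600 nM in a functional assay on HEK293 cells for activation of melanin-concentrating hormone receptor 1 (Homo sapiens), read by inositol phosphate accumulation; on this read-out lower numbers stand for an effect already at smaller amounts and higher numbers for an effect only at larger amounts of compound.
Compound 2, `CCCc1cc(N)c2cc(NC(=O)/C=C/c3ccc(SC)cc3)ccc2n1`, gives 71 nM in this assay.
Compound 3, `CCCc1cc(N)c2cc(NC(=O)/C=C/c3ccc(C(C)(C)C)cc3)ccc2n1`, gives 910 nM in this assay.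

On these three numbers compound 3 stands second highest: its nearest neighbour is compound 1, with a 4.0-fold lower number from compound 1 to compound 3 (0.60 log units; beyond the scatter), and its furthest is compound 2, with a 13-fold higher number from compound 2 to compound 3 (1.11 log units; beyond the scatter). The unmeasured compound 4, `CCCCc1ccc(/C=C/C(=O)Nc2ccc3nc(CCC)cc(N)c3c2)cc1`, keeps every atom of compound 3 but joins them differently: butyl in place of tert-butyl on an aromatic carbon.

For the measured compounds named here, only one measured step bears on this change directly. The move from an unbranched chain to a branched one on this carbon, a 4.0-fold lower number from compound 1 to compound 3 (0.60 log units; beyond the scatter), was modest and lowered the number; compound 4 reverses that branching while keeping the chain one carbon longer than in compound 1. The large step of a 51-fold lower number from compound 1 to compound 2 (1.71 log units; beyond the scatter) concerns a sulfur-containing group and offers no guidance for a plain chain. Nothing measured here pairs butyl with tert-butyl.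

Compound 4 is therefore expected to give a number somewhat above compound 3 and nearer compound 1, a modest step of a 2.0-fold higher number from compound 3 to compound 4 (0.30 log units; within the scatter) in this assay. The estimate for compound 4 is 1800 nM, with a range from 600 nM to 5400 nM.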

Compound 4, half-maximal effective concentration: 740 nM
Beside the measured number, compound 4's estimate is 2.4-fold (0.39 log units) above it; the measured number falls inside the stated range.
By their numbers in this assay, from the lowest: compound 2; then compounds 4 and 3 (each within the scatter of the next); then compound 1.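

In this assay, at this place para to a large group, joining the same 4 carbon atoms as tert-butyl or as butyl makes no difference that can be read (a 1.2-fold lower number from compound 3 to compound 4 (0.09 log units; within the scatter)), so the branching that compound 3 alone could not separate from chain size is not needed for its distance from compound 1. Compound 4 shows this with an unbranched chain, since a single methyl on the end of the propyl chain already carries the step (a 4.9-fold lower number from compound 1 to compound 4 (0.69 log units; beyond the scatter)), a step that is beyond the scatter, though the three alkyl compounds still leave methylsulfanyl well apart (a 10-fold higher number from compound 2 to compound 4 (1.02 log units; beyond the scatter)). Nothing given here explains why either butyl or tert-butyl differs from propyl or from methylsulfanyl.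

The compounds shown leave open whether a longer chain such as pentyl or hexyl would continue the step seen from propyl to butyl or lose it. They also leave open whether the sulfur of methylsulfanyl is what sets compound 2 apart, which a methoxy or an ethyl group at this place could test, and whether ethylsulfanyl would hold that number.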